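Does One More Methyl Shift Cytotoxicity?

The source may report more compounds than this note shows. Statements on the series, on what has been measured and on what is new or still open speak of the compounds shown alone.

Compound 1 `COC1=C(C)C(=O)/C(=C(O)/C=C/c2ccc(OC)cc2)C(=O)C1(C)C`: 18.2 ug/mL
Compound 2 `COC1=C(C)C(=O)/C(=C(O)/C=C/c2c(C)cccc2C)C(=O)C1(C)C`: 17.1 ug/mL

In a functional assay on PC-3 cells (Homo sapiens) for cytotoxicity (on this read-out lower numbers stand for an effect already at smaller amounts and higher numbers for an effect only at larger amounts of compound), compound 2 gives 17.1 ug/mL, which cannot be told apart from the value of compound 1. Compound 3 `COC1=C(C)C(=O)/C(=C(O)/C=C/c2c(C)cc(C)cc2C)C(=O)C1(C)C` differs from compound 2 in one place: methyl in place of hydrogen on an aromatic carbon. For the measured compounds named here, the only measured step, a 1.1-fold lower number from compound 1 to compound 2 (0.03 log units; within the scatter), replaced 4-methoxyphenyl with 2,6-dimethylphenyl and stayed within the scatter. It does not test this methyl directly, but it gives no reason to expect a large change. The expected step is a 1.1-fold lower number from compound 2 to compound 3 (0.03 log units; within the scatter), with no shift expected beyond the scatter. Compound 3 is estimated at 16 ug/mL, with an expected range of 8 ug/mL to 30 ug/mL.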

Compound 3, concentration for half-maximal effect: > 20 ug/mL
Compound 3: a limit, no number (the forecaster's own chance of this, stated with the estimate: 5%); at least 1.2-fold (0.09 log units) between middle value and limit.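

In this assay, for the compounds shown here, putting methyl in place of hydrogen on the aromatic carbon para to a large group gives an at least 1.1-fold higher number from compound 2 to compound 3 (0.06 log units; that floor lies within the scatter) and is the first direct test of this position. Compound 3 reads only as a limit, not a number: the limit of > 20 ug/mL in this assay, at which 1 of the 3 values shown sits. From the compounds shown here alone, this methyl therefore gives no lower number, while the true size of the rise stays unknown.

Going by these compounds, whether a different group on this carbon, such as an amine, a carboxylic acid or a longer chain, would give a measurable number remains open.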